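This account rests on a few compounds, and the source may have more. Where it says the series, first, only, none or still open, it means among the compounds named here.

Measured so far in a functional assay on the whole organism (Tail, strain ICR) with Mus musculus as the target, in the tail flick test, with a stated time of 150 min, at a dose of 25 umol/kg by the oral route; on this read-out lower numbers stand for a weaker effect and higher numbers for a stronger effect at the one dose given:
compound 1, `O=C(O)CC[C@H](NC(=O)CN(c1nc(Cl)nc2[nH]cnc12)C1CC1)C(=O)O`, gives 29.5%;
compound 2, `O=C(O)C[C@H](NC(=O)CN(c1nc(Cl)nc2[nH]cnc12)C1CC1)C(=O)O`, gives 11.6%;
compound 3, `NC(=O)CC[C@H](NC(=O)CN(c1nc(Cl)nc2[nH]cnc12)C1CC1)C(=O)O`, gives 11.4%.

Compound 3 stands lowest of the three numbers in this assay, though its gap to compound 2 is within the scatter; only compound 1 lies beyond it, as the step of a number 18.1 percentage points lower from compound 1 to compound 3 (beyond the scatter) shows. Compound 4, `CC(C)[C@H](NC(=O)CN(c1nc(Cl)nc2[nH]cnc12)C1CC1)C(=O)O`, is not yet measured. The change is isopropyl in place of 2-carbamoylethyl on a saturated chain carbon bound to an amide-type nitrogen and a carbonyl carbon. Among the measured compounds shown here, no measured step matches it: the steps of a number 17.9 percentage points lower from compound 1 to compound 2 (beyond the scatter) and a number 0.2 percentage points lower from compound 2 to compound 3 (within the scatter) concern carboxy and carbamoyl groups on the chain, not an isopropyl group. For compound 4 no step beyond the scatter is therefore expected, a number 1.6 percentage points higher from compound 3 to compound 4 (within the scatter), with wide uncertainty. The estimate for compound 4 in this assay is 13%, ranging from 3% to 30%.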

Compound 4, a percentage reported as activity, at one dose (the size of the read-out at that dose, not a potency): 7.86%
The estimate for compound 4 lay 5.1 percentage points above the measured number; the measured number falls inside the stated range.
By their numbers in this assay, from the lowest: compounds 4, 3 and 2 (each within the scatter of the next); then compound 1.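

In this assay, isopropyl on the saturated chain carbon bound to an amide-type nitrogen and a carbonyl carbon cannot be told apart from 2-carbamoylethyl (a number 3.5 percentage points lower from compound 3 to compound 4 (within the scatter)) or carboxymethyl (a number 3.7 percentage points lower from compound 2 to compound 4 (within the scatter)). Only 2-carboxyethyl stands clear of isopropyl (a number 21.6 percentage points lower from compound 1 to compound 4 (beyond the scatter)), so a side chain with neither carboxy nor carbamoyl still sits with compound 2 and compound 3, and compound 1 remains the lone outlier. No evidence here accounts for this result.

Open, going by these compounds, is whether a longer chain ending in a carboxylic acid would stay with compound 1. On these data alone, an amine at the chain end also remains untested against 2-carboxyethyl.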